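The source may report more compounds than this note shows. Statements on the series, on what has been measured and on what is new or still open speak of the compounds shown alone.

Three compounds measured:

Compound 1 `COc1ccc(-c2[nH]c3ccccc3c2/C=C(\C#N)S(=O)(=O)c2ccccc2)cc1` — 254 nM
Compound 2 `COc1ccc2[nH]c(-c3ccccc3)c(C=C(C#N)C#N)c2c1` — 2100 nM
Compound 3 `CCOC(=O)C(=Cc1c(-c2ccccc2)[nH]c2ccccc12)C(=O)OCC` — 4900 nM

In a functional assay on COLO 205 cells (Homo sapiens) for inhibition, read by sulforhodamine B assay, with a stated time of 48 h (on this read-out higher numbers stand for weaker inhibition of growth and lower numbers for stronger inhibition of growth), compound 1 gives 254 nM, the lowest of the three numbers and therefore the strongest growth inhibition in this set. Compound 2 gives 2100 nM, a gap that lies beyond the usual scatter, and compound 3 gives 4900 nM, the widest gap from compound 1. Compounds 2 and 3 each differ from compound 1 in more than one place, so their values show only where they stand, not what any single change does.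

The step followed here is from compound 1 to compound 4 `COc1ccc(-c2[nH]c3ccc(OC)cc3c2/C=C(\C#N)S(=O)(=O)c2ccccc2)cc1`. The change is methoxy in place of hydrogen on an aromatic carbon — methoxy in place of hydrogen on an aromatic carbon of the fused core, while the rest of compound 1 is kept. For the measured compounds named here, no pair of measured compounds isolates this change, so the data give no direct guide to its size or direction. With nothing in the measured set pointing either way, a step no larger than the scatter is expected: a 1.2-fold lower number from compound 1 to compound 4 (0.06 log units; within the scatter). Compound 4 is therefore estimated at 220 nM, with a range from 70 nM to 700 nM in this assay.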

Compound 4, concentration for 50% growth inhibition: 396 nM
The estimate for compound 4 lay 1.8-fold (0.26 log units) below the measured number, and the stated range covers the measured number.
By their numbers in this assay, from the lowest: compounds 1 and 4 (each within the scatter of the next); then compound 2; then compound 3.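

In this assay, for the compounds shown here, the replacement of hydrogen by methoxy on an aromatic carbon of the fused core gives a 1.6-fold higher number from compound 1 to compound 4 (0.19 log units; within the scatter) and so provides the only direct reading of a single change in this set, which the earlier compounds could not supply. At this carbon, meta to a fused ring and para to a fused ring, the added methoxy leaves compound 1 and compound 4 within the usual scatter of each other, so the two cannot be told apart on this read-out. No measurement is at hand that would explain this result.

The compounds shown leave open whether an amine, a hydroxyl group, a fluorine atom or a longer chain such as butoxy at this same carbon would also stay within the scatter of compound 1 or move beyond it. They also leave open whether methoxy at this carbon would give a similar step on the core of compound 3, which carries two ethyl ester groups in place of the nitrile and the phenyl sulfone of compound 1.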